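The compounds below may be only part of what the source reports. "The series", "measured", "known", "first", "only" and "open" are said of these compounds alone.

Measured compounds:
compound 1 `CC(C)(C)c1cc(NC(=O)c2c(Cl)cc(NCc3cccs3)cc2Cl)ccc1O` gives 8600 nM in an assay on isolated protein for antagonist activity at Bile acid receptor (Homo sapiens), read by HTRF, with a stated time of 30 min; on this read-out higher numbers stand for weaker inhibition and lower numbers for stronger inhibition
compound 2 `CC(C)(C)c1cc(NC(=O)c2c(Cl)cc(NC3CCCCC3)cc2Cl)ccc1O` gives 2500 nM in this assay
compound 3 `CN(C)c1cc(Cl)c(C(=O)N(C)c2ccc(O)c(C(C)(C)C)c2)c(Cl)c1` gives 3900 nM in this assay

Compound 3 stands second highest of the three numbers; against compound 2 the gap is within the scatter, while compound 1 sits higher by a step beyond the scatter. Going by the values given here, the only single-place step measured so far is a 3.4-fold lower number from compound 1 to compound 2 (0.54 log units; beyond the scatter), and it concerns the substituent on the aniline-type nitrogen of the shared core, not the amide nitrogen.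

Compound 4 `CN(C)c1cc(Cl)c(C(=O)N(Cc2cccnc2)c2ccc(O)c(C(C)(C)C)c2)c(Cl)c1` differs from compound 3 by pyridin-3-yl in place of hydrogen on a saturated chain carbon bound to an amide-type nitrogen. Among the compounds with values here, no measured pair changes this position, so the step from compound 1 to compound 2 does not bear on it directly; it shows only that a change of a ring-bearing side chain moves the number by a modest amount. The step in this assay is therefore expected to be small and of uncertain direction, a 1.1-fold lower number from compound 3 to compound 4 (0.05 log units; within the scatter), with wide uncertainty. For compound 4 the estimate is 3500 nM, within the range 1000 nM to 12000 nM.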

Compound 4, half-maximal inhibitory concentration: 6300 nM
Beside the measured number, compound 4's estimate is 1.8-fold (0.26 log units) below it; measured number inside the range.
By their numbers in this assay, from the lowest: compounds 2, 3, 4 and 1 (each within the scatter of the next, the first and the last beyond it).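

In this assay, going by these compounds alone, the change from methyl to (pyridin-3-yl)methyl on the amide-type nitrogen gives a 1.6-fold higher number from compound 3 to compound 4 (0.21 log units; within the scatter) as the first reading at this position. The position therefore carries a six-membered aromatic ring on a saturated chain carbon without a shift beyond the scatter, whereas the earlier step concerned only the other nitrogen substituent. No measurement shown accounts for this result.

The compounds shown leave open whether the ring nitrogen of pyridin-3-yl plays any part, which a benzyl group at this place would test, and whether a longer chain or a carboxylic acid here gives a similar number. Also open, on these data alone, is whether the same change reads alike when cyclohexyl, as in compound 2, stands on the other nitrogen.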